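The source may hold more compounds than are shown below. What is called first, only, known or untested is meant among the compounds shown, and "the series" means these compounds.

Compound 3 `COc1cc2nc(N3CCN(S(=O)(=O)c4ccc(I)cc4)CC3)nc(N)c2cc1OC` gives 15000 nM in a functional assay on PC-3 cells (Homo sapiens) for inhibition (a lower number here means a stronger inhibitor, a higher number a weaker inhibitor), the lowest of the two numbers shown, and compound 1 `COc1ccc(C(=O)N2CCN(c3nc(N)c4cc(OC)c(OC)cc4n3)CC2)cc1OC` gives 71000 nM in this assay, a gap beyond the usual scatter. Compound 2 `COc1cc2nc(N3CCN(C(=O)c4ccc(C(F)(F)F)cc4)CC3)nc(N)c2cc1OC` reaches only a limit of the assay in this assay, namely > 100000 nM. Compound 4 `COc1ccc(S(=O)(=O)N2CCN(c3nc(N)c4cc(OC)c(OC)cc4n3)CC2)cc1` differs from compound 3 by methoxy in place of iodo on an aromatic carbon. Going by the values given here, the only measured step, an at least 1.4-fold higher number from compound 1 to compound 2 (0.14 log units; that floor lies within the scatter), concerns a ring on a carbonyl carbon and not the ring changed here, so it bears only loosely; no measured step replaces iodo by methoxy. The expected step is a 2.0-fold higher number from compound 3 to compound 4 (0.30 log units; within the scatter), a modest rise. Compound 4 is estimated at 30000 nM, within 10000 nM to 100000 nM.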

Compound 4, half-maximal inhibitory concentration: 39000 nM
Beside the measured number, compound 4's estimate is 1.3-fold (0.11 log units) below it, and the stated range covers the measured number.
By their numbers in this assay, from the lowest: compound 3; then compounds 4 and 1 (each within the scatter of the next). At a limit, above all of these: compound 2.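

In this assay, the para position of the ring on the sulfonyl group is sensitive to substitution: swapping iodo for methoxy gives a 2.6-fold higher number from compound 3 to compound 4 (0.41 log units; beyond the scatter). The change is modest, but unlike the earlier step, its size is a measured one rather than a limit, and here iodo gives the lower number. Nothing shown here accounts for the difference. The compounds shown leave open how an amine or a carboxylic acid would read at this position. They also leave open whether any group there could bring the number well below that of compound 3.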